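The source may report more compounds than this note shows. Statements on the series, on what has been measured and on what is new or still open speak of the compounds shown alone.

Measured compounds:
compound 1, `NCCCCN(C[C@H]1Cc2ncccc2CN1)[C@H]1CCCc2cccnc21`: 100%
compound 2, `NCCCCN(C[C@@H]1Cc2ncccc2CN1)[C@H]1CCCc2cccnc21`: 98%

In an ADME assay on microsomes from liver (Homo sapiens) for metabolic stability, using NADPH, with a stated time of 10 min (on this read-out lower numbers stand for a less stable compound and higher numbers for a more stable compound), compound 1 gives 100% and compound 2 gives 98%; the step of a number 2 percentage points lower from compound 1 to compound 2 (within the scatter) is within the scatter, so both compounds sit at the same level, with nothing of the compound lost over the run. The two differ only in configuration as drawn (the fact that compounds 1 and 2 differ only in the configuration as drawn).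

Compound 3, `c1cnc2c(c1)CN[C@@H](CN(CCCCN(C1COC1)C1COC1)[C@H]1CCCc3cccnc31)C2`, differs from compound 1 by a group of 9 heavy atoms (6 carbon, 1 nitrogen, 2 oxygen; 2 four-membered non-aromatic rings with 1 hetero atom each) in place of one nitrogen atom, on a saturated chain carbon, four bonds along the chain from an amine nitrogen. Among the measured compounds shown here, the single measured step, a number 2 percentage points lower from compound 1 to compound 2 (within the scatter), concerns configuration alone and says nothing about a replacement of this kind, so no step beyond the scatter can be derived from it in either direction. Compound 1 already stands at full retention, which leaves room only for a fall or for no change. A modest fall is expected for compound 3, as the step of a number 15 percentage points lower from compound 1 to compound 3 (beyond the scatter). The estimate for compound 3 in this assay is 85%, with a range from 55% to 100%.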

Compound 3, percent of the compound remaining: 62%
Estimate against measurement, compound 3: 23 percentage points above; the measured number falls inside the stated range.
By their numbers in this assay, from the lowest: compound 3; then compounds 2 and 1 (each within the scatter of the next).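

In this assay, among the compounds shown here, the place on a saturated chain carbon, four bonds along the chain from an amine nitrogen, is the first where a change moves the read-out beyond the scatter: putting the group with 2 four-membered non-aromatic rings in place of the amino group gives a number 38 percentage points lower from compound 1 to compound 3 (beyond the scatter). Compounds 1 and 2 showed one level across a change in configuration, whereas this result shows that the shared core alone does not secure full retention and that the group at this place can lower it substantially. Nothing measured here bears on the cause of this fall.

On these data alone, it remains open whether the fall follows from losing the amino group or from the entering group itself. A dimethylamino group or a carboxylic acid at this place would help separate the two readings.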